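The compounds below may be only part of what the source reports. "The series", "measured", "known", "first", "only" and "open" are said of these compounds alone.

Three compounds with a shared core have been looked at in a functional assay on MCF7 cells (Homo sapiens) for inhibition, read by MTT assay, with a stated time of 72 h (a higher number here means a weaker inhibitor, a lower number a stronger inhibitor), and only one of them has a number. Compound 1, `O=C(NNC(=O)C1CC1c1ccc(OC(F)(F)F)cc1)c1ccncc1`, has no reported result in this assay, standing at "not determined" (no result reported). Compound 2, `CCOc1ccc(C2CC2C(=O)NNC(=O)c2ccncc2)cc1`, likewise has no reported result in this assay, standing at "not determined" (no result reported). Compound 3, `COc1ccc(C2CC2C(=O)NNc2nncc3ccccc23)cc1`, is the only one with a figure: in this assay compound 3 gives 72000 nM, a weak inhibition.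

Compound 4, `O=C(NNc1nncc2ccccc12)C1CC1c1ccc(OCC(F)(F)F)cc1`, is built from compound 3 by one change: trifluoromethyl in place of hydrogen on a saturated chain carbon bound to an oxygen on an aromatic ring. For the measured compounds named here, no pair of measured compounds shows this change, so nothing in the data says how large a step it brings or in which direction. With the only anchor being the weak figure of compound 3, the plain expectation is a step not beyond the usual scatter of this assay; the estimated step from compound 3 to compound 4 in this assay is a 1.2-fold lower number from compound 3 to compound 4 (0.08 log units; within the scatter). Compound 4 is therefore expected to give about 60000 nM in this assay, with a range from 20000 nM to 200000 nM.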

Compound 4, half-maximal inhibitory concentration: 8000 nM
Compound 4: middle estimate off by 7.5-fold (0.88 log units), on the high side, outside the stated range (below it).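

In this assay the move from methoxy to 2,2,2-trifluoroethoxy brings a 9.0-fold lower number from compound 3 to compound 4 (0.95 log units; beyond the scatter), so this position is not indifferent to what it carries. For the compounds shown here, the single figure for compound 3 could not show that; this pair is the first sign that trifluoromethyl in place of hydrogen on a saturated chain carbon bound to an oxygen on an aromatic ring can clearly shift the number, and it is one pair only. No measurement here explains the shift.

The compounds shown leave open whether the fluorine atoms or the added chain carbon carry the step, a question a plain ethoxy group on the core of compound 3 would speak to. On these data alone, how a longer chain such as propoxy, or an amine at the chain end, would fare at this position also stays open.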